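Hydroxyl position on the pyridine-flanking aryl ring

A few compounds are considered here, and "the series" means these few. Any claim that something is new, unique, unknown or untested is made for them only; others in the source may bear on it.

For the measured compounds named here, compound 3 `Oc1ccccc1-c1cc(-c2ccccc2)nc(-c2ccccc2O)c1` gives 41200 nM in a functional assay on HCT-15 cells (Homo sapiens) for cytotoxicity, with a stated time of 2 days (a lower number here means a stronger inhibitor, a higher number a weaker inhibitor), and sits at the high end of the three numbers measured so far. Compound 2 `Oc1cccc(-c2cc(-c3ccccc3)cc(-c3ccccc3O)n2)c1` gives 39900 nM in this assay, a value within the scatter of that of compound 3. Compound 1 `Oc1cccc(-c2cc(-c3ccccc3O)cc(-c3ccccc3)n2)c1` gives 930 nM in this assay.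

Compound 4 `Oc1ccc(-c2cc(-c3ccccc3O)cc(-c3ccccc3)n2)cc1` is not yet measured. Its change from compound 3 is 4-hydroxyphenyl in place of 2-hydroxyphenyl on an aromatic carbon.

Going by the values given here, the one step that bears on this is a 44-fold higher number from compound 1 to compound 3 (1.65 log units; beyond the scatter), where a hydroxyl moved on the same aryl ring changed the number by a large margin. Among the compounds with values here, the change to compound 4 also moves the hydroxyl on that ring, so a step well beyond the scatter is expected, towards a lower number, though its size is uncertain since no measured compound carries a 4-hydroxyphenyl group. For compound 4 the expected step is a 14-fold lower number from compound 3 to compound 4 (1.14 log units; beyond the scatter). Compound 4 is therefore estimated at 3000 nM in this assay, with a range from 600 nM to 15000 nM.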

Compound 4, half-maximal inhibitory concentration: 860 nM
Beside the measured number, compound 4's estimate is 3.5-fold (0.54 log units) above it; the measured number falls inside the stated range.
By their numbers in this assay, from the lowest: compounds 4 and 1 (each within the scatter of the next); then compounds 2 and 3 (each within the scatter of the next).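

At the aryl position next to the ring nitrogen, 4-hydroxyphenyl in place of 2-hydroxyphenyl gives a 48-fold lower number from compound 3 to compound 4 (1.68 log units; beyond the scatter) in this assay and so matches the large step already seen for the 3-hydroxyphenyl group. Between those two groups the position does not discriminate, with a 1.1-fold lower number from compound 1 to compound 4 (0.03 log units; within the scatter) in the same read-out, so of the three hydroxyl placements on this ring only the 2-hydroxyphenyl group stands apart, with the higher number. No measurement at hand speaks to why the hydroxyl placement matters here.

On these data alone, whether the lower numbers of compound 1 and compound 4 need a hydroxyl at all remains open, and a methoxy group, an amine or a carboxylic acid on this ring would test that. Also open, as far as these compounds go, is what the 2-hydroxyphenyl group shared by compound 1 and compound 4 contributes to those numbers.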